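Compound 3 to compound 4: a pyridin-3-yl swap

A few compounds are considered here, and "the series" means these few. Any claim that something is new, unique, unknown or untested is made for them only; others in the source may bear on it.

Measured in a functional assay on MDA-MB-231 cells (Homo sapiens) for inhibition, read by MTT assay, with a stated time of 48 h; a higher number here means a weaker inhibitor of growth, a lower number a stronger inhibitor of growth:
- compound 1 `Oc1ccc(NC(=S)Nc2ccc3ncnc(Nc4cccc(Br)c4)c3c2)cc1`: 17300 nM
- compound 2 `FC(F)(F)c1ccc(NC(=S)Nc2ccc3ncnc(Nc4cccc(Br)c4)c3c2)cc1`: 12200 nM
- compound 3 `S=C(Nc1cc(Cl)cc(Cl)c1)Nc1ccc2ncnc(Nc3cccc(Br)c3)c2c1`: 3000 nM

Of these three, compound 3 has the lowest number, 3000 nM, which makes it the strongest inhibitor of growth in the set. Compound 4 `S=C(Nc1cccnc1)Nc1ccc2ncnc(Nc3cccc(Br)c3)c2c1` has not been measured yet. It keeps the shared core and changes one group: pyridin-3-yl in place of 3,5-dichlorophenyl on an amide-type nitrogen. In words, this is pyridin-3-yl in place of 3,5-dichlorophenyl on an amide-type nitrogen.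

Two measured steps change the group at this same place and both end at the 3,5-dichlorophenyl group: a 5.8-fold lower number from compound 1 to compound 3 (0.76 log units; beyond the scatter) and a 4.1-fold lower number from compound 2 to compound 3 (0.61 log units; beyond the scatter). Both are modest. The other step, a 1.4-fold lower number from compound 1 to compound 2 (0.15 log units; within the scatter), shows no real separation between the two groups it compares. For the measured compounds named here, no measured compound carries pyridin-3-yl, so any forecast is a cautious extrapolation. Leaving 3,5-dichlorophenyl raised the number in both measured cases, so a modest rise of similar size is expected in this assay. The expected change is a 3.7-fold higher number from compound 3 to compound 4 (0.56 log units; beyond the scatter). For compound 4 the estimated value is 11000 nM, with an expected range from 4500 nM to 28000 nM.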

Compound 4, concentration for 50% growth inhibition: > 30000 nM
Compound 4 gave a limit, no number; the forecaster's own chance of this, stated with the estimate: 10%; middle value at least 2.7-fold (0.43 log units) from the limit.
By their numbers in this assay, from the lowest: compound 3; then compounds 2 and 1 (each within the scatter of the next). At a limit, above all of these: compound 4.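

Compound 4 gives a limit of the assay and not a number: the limit of > 30000 nM in this assay, at which 1 of the 4 values shown sits. Even so, pyridin-3-yl on this amide-type nitrogen gives an at least 10-fold higher number from compound 3 to compound 4 (1.00 log units; beyond the scatter) and an at least 2.4-fold higher number from compound 2 to compound 4 (0.39 log units; beyond the scatter), so the group at this place can push the number further up than the three earlier compounds showed. Against the hydroxy-bearing group the floor is smaller, an at least 1.7-fold higher number from compound 1 to compound 4 (0.23 log units; that floor lies within the scatter), so compound 4 cannot yet be set apart from compound 1.

Compound 4 loses the two chlorines and brings a ring nitrogen in one change, and the compounds shown cannot tell which of the two matters. A plain phenyl group would isolate the loss of chlorine, and a dichloropyridinyl group would isolate the ring nitrogen.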